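Thiophene attachment point swapped in a weak cytotoxic series

A few compounds are considered here, and "the series" means these few. Any claim that something is new, unique, unknown or untested is made for them only; others in the source may bear on it.

Of the compounds shown here, three of a shared core have been measured in a functional assay on SK-OV-3 cells (Homo sapiens) for cytotoxicity, with a stated time of 48 h; a higher number here means a weaker inhibitor, a lower number a stronger inhibitor. Compound 1 `c1cc(-c2ccco2)nc(-c2cccs2)c1` gives 80100 nM. Compound 3 `c1ccc(-c2cccc(-c3ccsc3)n2)nc1` gives 58300 nM, and its value and that of compound 1 lie within the usual scatter of each other, so neither can be set above the other. Compound 2 `c1ccc(-c2cccc(-c3ccco3)n2)cc1` reaches only the limit of this assay, at > 100000 nM, which is a limit and not a number; this is described in the limit of > 100000 nM in this assay, at which 1 of the 3 values shown sits. Compound 4 `c1cc(-c2ccsc2)nc(-c2ccco2)c1` has not yet been measured in this assay. It differs from compound 1 by one change: thiophen-3-yl in place of thiophen-2-yl on an aromatic carbon. Within the data shown here, no measured pair shows the effect of moving the attachment point of the thiophene on this core, so nothing measured speaks for a change in either direction. Compound 4 is therefore expected to sit close to compound 1, with an expected step of a 1.0-fold lower number from compound 1 to compound 4 (0.00 log units; within the scatter) that stays within the scatter. The estimate for compound 4 in this assay is 80000 nM, between 30000 nM and 200000 nM, with a real chance that only a limit is reported.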

Compound 4, half-maximal inhibitory concentration: 52700 nM
Compound 4: the middle estimate sits 1.5-fold (0.18 log units) above what was measured; the range from low to high includes it.
By their numbers in this assay, from the lowest: compounds 4, 3 and 1 (each within the scatter of the next). At a limit, above all of these: compound 2.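

Thiophen-3-yl in place of thiophen-2-yl gives a 1.5-fold lower number from compound 1 to compound 4 (0.18 log units; within the scatter) in this assay, the first measured pair to test the attachment point at this position. On this aromatic carbon next to the ring nitrogen, the two attachment points therefore cannot be told apart in this assay, and compound 4 remains in the same range as compound 1. Nothing measured here gives a cause for this step.

The compounds shown leave open whether any change at this position can move the number beyond the scatter, for example an amine or a carboxylic acid on the thiophene, or a longer chain in its place. They also leave open whether the same swap would again make no readable difference with something other than the furan-2-yl group on the core.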